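The source may report more compounds than this note shows. Statements on the series, on what has been measured and on what is new or still open speak of the compounds shown alone.

Measured values in a functional assay on M21 cells (Homo sapiens) for antiproliferative activity, read by sulforhodamine B assay, with a stated time of 48 h (a lower number here means a stronger inhibitor, a higher number a weaker inhibitor), for the series
- compound 1 `Cc1ccc(OS(=O)(=O)c2ccc(N3CCN(C)C3=O)cc2)c(C)c1` gives 1800 nM
- compound 2 `CN1CCN(c2ccc(S(=O)(=O)Oc3cccc(F)c3)cc2)C1=O` gives 5800 nM
- compound 3 `CN1CCN(c2ccc(S(=O)(=O)Oc3ccc(F)cc3)cc2)C1=O` gives > 100000 nM which is a limit of the assay and not a number

Compound 2 holds the higher of the two numeric values, and its nearest neighbour is compound 1 (a 3.2-fold higher number from compound 1 to compound 2 (0.51 log units; beyond the scatter)), a modest step beyond the scatter.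

Next in line is compound 4 `CCN1CCN(c2ccc(S(=O)(=O)Oc3cccc(F)c3)cc2)C1=O` with 3-ethyl-2-oxoimidazolidin-1-yl in place of 3-methyl-2-oxoimidazolidin-1-yl. The change is methyl in place of hydrogen on a saturated chain carbon bound to an amide-type nitrogen in a ring.

For the measured compounds named here, no measured step touches this group. All three change only the aryl group on the oxygen, so they bear on the new step only indirectly. They show how far values can move within the series, from the modest 3.2-fold higher number from compound 1 to compound 2 (0.51 log units; beyond the scatter) to the large at least 17-fold higher number from compound 2 to compound 3 (1.23 log units; beyond the scatter) and an at least 55-fold higher number from compound 1 to compound 3 (1.74 log units; beyond the scatter). Going by the values given here, with no direct precedent, no direction is favoured, and the expectation starts from compound 2 (5800 nM) with a wide margin.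

In this assay the expected change is none beyond the scatter, with an estimated 1.0-fold higher number from compound 2 to compound 4 (0.01 log units; within the scatter) as the working figure. For compound 4 the estimated value is 6000 nM with an expected range from 1500 nM to 25000 nM in this read-out.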

Compound 4, half-maximal inhibitory concentration: 11000 nM
For compound 4 the middle estimate is 1.8-fold (0.26 log units) below the measured one; low and high end bracket the measured number.
By their numbers in this assay, from the lowest: compound 1; then compounds 2 and 4 (each within the scatter of the next). At a limit, above all of these: compound 3.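

In this assay the replacement of 3-methyl-2-oxoimidazolidin-1-yl by 3-ethyl-2-oxoimidazolidin-1-yl, which turns methyl into ethyl on the amide-type nitrogen in the ring, gives a 1.9-fold higher number from compound 2 to compound 4 (0.28 log units; within the scatter). For the compounds shown here, the earlier steps changed only the aryl group on the oxygen, so this is the first reading at this position: with 3-fluorophenyl held constant, one added methyl on the saturated chain carbon leaves compounds 2 and 4 at one level within the scatter, and the position accepts ethyl in this assay. No measurement shown here bears on a cause for this small step.

As far as these compounds go, a single step gives no trend at this position, and it remains open whether a longer chain such as propyl or butyl, a bulkier group such as cyclopropyl, or a chain ending in an amine or a carboxylic acid would keep the value within the scatter of compound 2. From the compounds shown here alone, it also remains open whether ethyl reads the same when the aryl group on the oxygen is 2,4-dimethylphenyl or 4-fluorophenyl rather than 3-fluorophenyl.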